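From iodo to bromo: an expected cytotoxicity step

The source may hold more compounds than are shown below. What is called first, only, known or untested is meant among the compounds shown, and "the series" means these compounds.

Measured so far in an ADME assay on MT4 cells (Homo sapiens) for cytotoxicity, read by MTT assay, with a stated time of 5 days (on this read-out lower numbers stand for higher toxicity in this test and higher numbers for lower toxicity in this test), are two compounds
compound 1 `Cc1cc(C)cc(Oc2cc(Nc3ccc(C#N)cc3)[nH]c(=O)c2I)c1` gives 24000 nM
compound 2 `Cc1cc(C)c(Oc2cc(Nc3ccc(C#N)cc3)[nH]c(=O)c2I)c(C)c1` gives 34000 nM

Within the data shown here, compound 1 stands within the scatter of compound 2, the only other number at hand. Compound 3 `Cc1cc(C)cc(Oc2cc(Nc3ccc(C#N)cc3)[nH]c(=O)c2Br)c1` differs from compound 1 by bromo in place of iodo on an aromatic carbon and so carries bromo in place of iodo on an aromatic carbon. Among the measured compounds shown here, the only measured step is a 1.4-fold higher number from compound 1 to compound 2 (0.15 log units; within the scatter) and it concerns the group on oxygen, not the halogen. For the measured compounds named here, no measured step covers this swap. In this assay no change beyond the scatter is therefore expected. The expected step is a 1.0-fold higher number from compound 1 to compound 3 (0.02 log units; within the scatter) and it stays within the scatter. For compound 3 the estimated value is 25000 nM with an expected range from 11000 nM to 55000 nM around that estimate.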

Compound 3, half-maximal cytotoxic concentration: 19000 nM
Compound 3: the middle estimate sits 1.3-fold (0.12 log units) above what was measured, and the stated range covers the measured number.
By their numbers in this assay, from the lowest: compounds 3, 1 and 2 (each within the scatter of the next).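

The halogen position now has a measured step of its own: in this assay, bromo in place of iodo on an aromatic carbon gives a 1.3-fold lower number from compound 1 to compound 3 (0.10 log units; within the scatter). This swap of one halogen for another therefore stays within the scatter, as the step on the group on oxygen did. Nothing at hand explains this result.

The compounds shown leave open whether chloro, an amine or a methyl group at this same position would also stay within the scatter. They also leave open whether bromo behaves alike with the 2,4,6-trimethylphenyl group on oxygen.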